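The source may report more compounds than this note shows. Statements on the series, on what has been measured and on what is new or still open speak of the compounds shown alone.

Working notes on a small set built on one shared core. Compound 1 `O=c1c(-c2nn[nH]n2)c[nH]c2c(Cl)ccc(Cl)c12` in a functional assay on the whole organism (strain Sprague-Dawley) for inhibition, with Rattus norvegicus as the target (on this read-out lower numbers stand for an effect already at smaller amounts and higher numbers for an effect only at larger amounts of compound), gives 0.312 mg/kg. Compound 2 `Cc1cccc2c(=O)c(-c3nn[nH]n3)c[nH]c12` in this assay returns only a limit of the assay, > 10 mg/kg, which is the limit of > 10 mg/kg in this assay, at which 1 of the 3 values shown sits. Compound 3 `O=c1c(-c2nn[nH]n2)c[nH]c2ccc(Cl)cc12` in this assay likewise returns only a limit, > 25 mg/kg, which is the limit of > 25 mg/kg in this assay, at which 1 of the 3 values shown sits. Compound 2 thus stands on a limit rather than a number, one of two such limits among the three values, while compound 1 alone has a measured dose.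

The step from compound 2 to compound 4 `O=c1c(-c2nn[nH]n2)c[nH]c2c(Br)cccc12` is bromo in place of methyl on an aromatic carbon. Among the compounds with values here, no step between measured compounds covers this change, so its effect in this assay cannot be read from the set. Since compound 1, carrying two chloro groups, gives 0.312 mg/kg, the bromo group is expected to bring compound 4 down to a measurable dose, and the expected step is an at least 3.3-fold lower number from compound 2 to compound 4 (0.52 log units; beyond the scatter), downward and beyond the scatter. Compound 4 is expected at 3 mg/kg, in a range from 0.5 mg/kg to 25 mg/kg.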

Compound 4, minimum effective dose: > 10 mg/kg
Compound 4 was reported as a limit (the forecaster's own chance of this, stated with the estimate: 35%); middle value at least 3.3-fold (0.52 log units) away from the limit.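

Within the data shown here, compound 2 and compound 4 both rest on limits in this assay, so no step between them can be read. The compounds shown leave open how bromo and methyl compare on this aromatic carbon, and at what dose, if any, either compound takes effect.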